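The compounds below may be only part of what the source reports. "The series", "measured", "known", "first", "only" and "open" are said of these compounds alone.

Measured compounds in the series:
compound 1 `COc1cc(-c2cc(C(=O)O)c3ccccc3n2)ccc1OCC(=O)Nc1ccccc1`: in an ADME assay on HaCaT cells (Homo sapiens) for inhibition (a higher number here means a weaker inhibitor, a lower number a stronger inhibitor), compound 1 reaches only the assay limit, > 300000 nM.
compound 2 `COc1cc(-c2cc(C(=O)O)c3ccccc3n2)ccc1OCC(=O)Nc1ccc(Cl)cc1`: in this assay compound 2 also stands only at the assay limit, > 300000 nM.

The step that the two limits leave unreadable from compound 1 to compound 2 has no readable size, since the limit of > 300000 nM in this assay, at which 2 of the 2 values shown sit, places both values at the limit. Compound 2 thus has no number, only a limit. Compound 3 `COc1cc(-c2cc(C(=O)O)c3ccccc3n2)ccc1OCC(=O)Nc1ccc(C(F)(F)F)cc1` differs from compound 2 by trifluoromethyl in place of chloro on an aromatic carbon. Going by the values given here, the single measured step bears on this change but gives no size, so the expectation for compound 3 rests on the two limits alone. Compound 3 is expected to stay near the limit, estimated at 400000 nM (range 150000 nM to 1500000 nM), an expected step that the limit leaves unreadable from compound 2 to compound 3.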

Compound 3, half-maximal inhibitory concentration: 150000 nM
Compound 3: middle estimate off by 2.7-fold (0.43 log units), on the high side; low and high end bracket the measured number.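

Trifluoromethyl on the aromatic carbon para to a large group gives the first number rather than a limit in this assay. Measured against the limits, this change gives an at least 2.0-fold lower number from compound 2 to compound 3 (0.30 log units; that floor lies within the scatter), and against hydrogen it gives an at least 2.0-fold lower number from compound 1 to compound 3 (0.30 log units; that floor lies within the scatter). Both are floors rather than sizes, and the step from hydrogen to chloro cannot be read: the limit of > 300000 nM in this assay, at which 2 of the 3 values shown sit.

From the compounds shown here alone, whether a nitrile or an amine at this place would also give a number rather than a limit remains open. Going by these compounds, how far the number falls below the limits for compound 1 and compound 2 also stays unknown.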